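The compounds below may be only part of what the source reports. "The series", "measured", "known", "first", "only" and "open" are said of these compounds alone.

Compound 1 (`[O-][S+](CCC(F)(F)C(F)(F)F)c1nc(-c2ccccc2)c(-c2ccccc2)[nH]1`) and compound 2 (`CCOc1ccc(-c2[nH]c(S(C)(=O)=O)nc2-c2ccccc2)cc1`) have both been tested in a functional assay on the whole organism with Mus musculus as the target, in the writhing test; on this read-out higher numbers stand for an effect only at larger amounts of compound and lower numbers for an effect already at smaller amounts. Compound 1 gives > 130 mg/kg as a limit of the assay, not a number. Compound 2 gives > 130 mg/kg as well, and this too is a limit, so no actual dose for half-maximal effect is known for it. Compound 3 (`Cc1ccc(-c2[nH]c(S(C)(=O)=O)nc2-c2ccccc2)cc1`) keeps the core of compound 2 and changes one group, with methyl in place of ethoxy on an aromatic carbon. Within the data shown here, no measured pair shows what this change does, so any forecast is uncertain. The expected change, an at least 1.1-fold lower number from compound 2 to compound 3 (0.07 log units; that floor lies within the scatter) in this estimate, is modest and toward smaller doses, and the assay may again report only a limit. For compound 3 the estimated dose is 110 mg/kg with an expected range of 40 mg/kg to 220 mg/kg in this assay.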

Compound 3, dose for half-maximal effect: > 130 mg/kg
Compound 3: no number, only a limit; the forecaster's own chance of this, stated with the estimate: 55%; at least 1.1-fold (0.07 log units) between middle value and limit.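

Compound 2 and compound 3 both give only a limit of the assay, not a number, so the step between them cannot be read: the limit of > 130 mg/kg in this assay, at which 3 of the 3 values shown sit. The compounds shown leave open whether methyl in place of ethoxy changes the dose for half-maximal effect at all, and in which direction.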